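This account rests on a few compounds, and the source may have more. Where it says the series, first, only, none or still open, it means among the compounds named here.

In a functional assay on SiHa cells (Homo sapiens) for antiproliferative activity, read by CCK-8 assay, with a stated time of 72 h (a higher number here means a weaker inhibitor, a lower number a stronger inhibitor), compound 1 `COc1ccc(-c2cncnc2-c2cc(OC)c(OC)c(OC)c2)cc1F` gives 3340 nM, and compound 2 `COc1ccc(-c2cncnc2-c2cc(OC)c(OC)c(OC)c2)cc1Cl` gives 1330 nM. Chloro in place of fluoro brings a 2.5-fold lower number from compound 1 to compound 2 (0.40 log units; beyond the scatter), a modest change.

Compound 3 `COc1cc(-c2ncncc2-c2ccc(C(N)=O)cc2)cc(OC)c1OC` gives > 100000 nM, which is a limit of the assay and not a number.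

Putting 4-carbamoylphenyl in place of 3-fluoro-4-methoxyphenyl gives an at least 29-fold higher number from compound 1 to compound 3 (1.47 log units; beyond the scatter), and putting it in place of 3-chloro-4-methoxyphenyl gives an at least 75-fold higher number from compound 2 to compound 3 (1.87 log units; beyond the scatter). Both steps are large.

Compound 4 `COc1cc(-c2ncncc2-c2ccc3cc[nH]c3c2)cc(OC)c1OC` carries 1H-indol-6-yl in place of 4-carbamoylphenyl on an aromatic carbon. Going by the values given here, no measured compound carries this new group, so the expectation rests on the large steps already seen. Losing 4-carbamoylphenyl should undo much of an at least 75-fold higher number from compound 2 to compound 3 (1.87 log units; beyond the scatter), so a large fall in the number is expected in this assay.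

The expected change is an at least 160-fold lower number from compound 3 to compound 4 (2.22 log units; beyond the scatter).

Compound 4 is estimated at 600 nM, with an expected range from 40 nM to 9000 nM.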

Compound 4, half-maximal inhibitory concentration: 2180 nM
The estimate for compound 4 lay 3.6-fold (0.56 log units) below the measured number; the range from low to high includes it.
By their numbers in this assay, from the lowest: compounds 2, 4 and 1 (each within the scatter of the next, the first and the last beyond it). At a limit, above all of these: compound 3.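

The loss seen with 4-carbamoylphenyl is not what every replacement at this position brings, since 1H-indol-6-yl gives an at least 45-fold lower number from compound 3 to compound 4 (1.66 log units; beyond the scatter) on the same aromatic carbon. Set against the earlier groups, it gives a 1.6-fold higher number from compound 2 to compound 4 (0.21 log units; within the scatter) and a 1.5-fold lower number from compound 1 to compound 4 (0.19 log units; within the scatter) even though it carries neither a halogen nor a methoxy group, so neither is needed here for activity of this order. The first of these steps is only a minimum, since one of its ends is a limit and not a number: the limit of > 100000 nM in this assay, at which 1 of the 4 values shown sits.

As far as these compounds go, whether the indole's ring nitrogen hydrogen matters remains open, and an N-methylindol-6-yl group would test that. Also open, from the compounds shown here alone, is whether the loss belongs to the carbamoyl group itself, which a phenyl ring bearing an amine or a carboxylic acid at that spot could help to show.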